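Swapping a Propyl for a Naphthyl on a Thiourea Core

The source may report more compounds than this note shows. Statements on the series, on what has been measured and on what is new or still open speak of the compounds shown alone.

Compound 3 `CCCC(=O)NC(=S)N1CCc2c(OCCCCCOc3ccc(Cl)cc3)cccc21` carries a propyl on the carbonyl carbon of its shared core. In an ADME assay on Huh-7 cells (Homo sapiens) for cytotoxicity (on this read-out lower numbers stand for higher toxicity in this test and higher numbers for lower toxicity in this test), compound 3 reaches only > 50000 nM, which is a limit of the test rather than a number. Compound 1 `O=C(NC(=S)N1CCc2c(OCCCCCOc3ccc(Cl)cc3)cccc21)c1ccc(F)cc1` gives 31100 nM in this assay. Compound 2 `Cc1ccc(C(=O)NC(=S)N2CCc3c(OCCCCCOc4ccc(Cl)cc4)cccc32)cc1` sits at > 50000 nM in this assay, again a limit. Compound 4 `O=C(NC(=S)N1CCc2c(OCCCCCOc3ccc(Cl)cc3)cccc21)c1ccc2ccccc2c1` differs from compound 3 as follows: naphthalen-2-yl in place of propyl on a carbonyl carbon. The nearest measured step runs from an aromatic group to propyl, an at least 1.6-fold higher number from compound 1 to compound 3 (0.20 log units; that floor lies within the scatter), while the other step into compound 3, a step that the two limits leave unreadable from compound 2 to compound 3, yields no size. Given that compound 1 with an aromatic group gives 31100 nM, compound 4 is expected to move by an at least 1.6-fold lower number from compound 3 to compound 4 (0.22 log units; that floor lies within the scatter), toward a somewhat lower number. The estimate for compound 4 is 30000 nM, ranging from 10000 nM to 60000 nM.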

Compound 4, half-maximal cytotoxic concentration: > 50000 nM
Compound 4 ended at the assay's limit (the forecaster's own chance of this, stated with the estimate: 40%); middle value at least 1.6-fold (0.22 log units) from the limit.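

Compound 4, with two aromatic rings on the carbonyl carbon, stays at the limit > 50000 nM in this assay, so a larger aromatic group alone does not bring the number down here. Replacing 4-fluorophenyl with naphthalen-2-yl gives an at least 1.6-fold higher number from compound 1 to compound 4 (0.20 log units; that floor lies within the scatter). The steps from compound 2 and compound 3 to compound 4 cannot be read, because both ends of each stop at the same ceiling: the limit of > 50000 nM in this assay, at which 3 of the 4 values shown sit.

Going by these compounds, how a group bearing an amine or a carboxylic acid would read on this carbonyl carbon stays open. So does how far the compounds at the limit lie from one another.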